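The source may hold more compounds than are shown below. What is called first, only, known or untested is meant among the compounds shown, and "the series" means these compounds.

Of the compounds shown here, three that share one core have been tested in a functional assay on A549 cells (Homo sapiens) for inhibition; a lower number here means a stronger inhibitor, a higher number a weaker inhibitor. Compound 1 `CCCCNC(=O)N1CC1C#N` gives 18000 nM, and compound 3 `CCNC(=O)N1CC1C#N` gives 18000 nM. Going by the values given here, the one step that joins two measured compounds, no change at the digits printed from compound 1 to compound 3 (within the scatter), shows that swapping hydrogen for ethyl on the chain does not move the number beyond the scatter. Compound 2 `N#CC1CN1C(=O)Nc1ccc(F)cc1` gives 6200 nM, the lowest of the three numbers; compound 1 and compound 3 both stand higher by a margin beyond the scatter, and by the same margin.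

Compound 4 `N#CC1CN1C(=O)Nc1ccc(S(N)(=O)=O)cc1` has not yet been measured in this assay. It differs from compound 2 by sulfamoyl in place of fluoro on an aromatic carbon. Among the compounds with values here, the single known step concerns a saturated chain carbon, not the aromatic ring, so nothing measured here speaks directly to a change on that ring. Without such a precedent, the soundest expectation is a step of no clear size in either direction, with a wide range to cover the uncertainty. Compound 4 is therefore expected to give about 6000 nM, within a range from 1500 nM to 25000 nM. That estimate means an expected step of a 1.0-fold lower number from compound 2 to compound 4 (0.01 log units; within the scatter), one that would stay within the scatter of this assay.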

Compound 4, half-maximal inhibitory concentration: > 38000 nM
Compound 4: only a limit was reported; the forecaster's own chance of this, stated with the estimate: 10%; middle value at least 6.3-fold (0.80 log units) away from the limit.
By their numbers in this assay, from the lowest: compound 2; then compounds 1 and 3 (each within the scatter of the next). At a limit, above all of these: compound 4.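

Going by these compounds alone, this is the first change on the aromatic ring, and unlike the change on the saturated chain, it moves the result in this assay well beyond the scatter: the swap of fluoro for sulfamoyl gives an at least 6.1-fold higher number from compound 2 to compound 4 (0.78 log units; beyond the scatter). The entry for compound 4 is a limit and not an exact number: the limit of > 38000 nM in this assay, at which 1 of the 4 values shown sits. The size of this step is therefore a minimum, but its direction is clear: this aromatic carbon, para to a group of 8 heavy atoms, does not accept every substituent equally, and sulfamoyl there gives a weaker inhibitor than fluoro.

With only fluoro and sulfamoyl shown at this carbon, it remains open how a chloro, a methoxy or an amine would compare, and whether any group there could give a lower number than fluoro does. From the compounds shown here alone, it also remains open which part of the swap matters, whether the added heavy atoms, the double bonds, or the hydrogen-bond donor and acceptors that enter with sulfamoyl, since all of them change together in this single step.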